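A Second Fluorine on the Pendant Phenyl Ring

The compounds below may be only part of what the source reports. "The series", "measured", "known", "first", "only" and "open" are said of these compounds alone.

Compound 1 `COc1cc2c(Oc3ccc(NC(=O)c4nccc(-c5ccccc5)n4)cc3F)ccnc2cc1OCCCN1CCCCC1`, compound 2 `COc1cc2c(Oc3ccc(NC(=O)c4nccc(-c5ccc(C)cc5)n4)cc3F)ccnc2cc1OCCCN1CCCCC1` and compound 3 `COc1cc2c(Oc3ccc(NC(=O)c4nccc(-c5ccc(F)cc5)n4)cc3F)ccnc2cc1OCCCN1CCCCC1` share one core and differ only in the substituent on the pendant phenyl ring. In a functional assay on MKN-45 cells (Homo sapiens) for cytotoxicity, read by MTT assay, with a stated time of 72 h (a higher number here means a weaker inhibitor, a lower number a stronger inhibitor), compound 1 gives 1030 nM, compound 2 gives 580 nM and compound 3 gives 930 nM. Compound 3 stands second highest of the three; its gaps to its nearest and its furthest neighbour both lie within the scatter: a 1.1-fold lower number from compound 1 to compound 3 (0.04 log units; within the scatter) and a 1.6-fold higher number from compound 2 to compound 3 (0.21 log units; within the scatter). Compound 4 `COc1cc2c(Oc3ccc(NC(=O)c4nccc(-c5ccc(F)cc5F)n4)cc3F)ccnc2cc1OCCCN1CCCCC1` takes the step (fluoro in place of hydrogen on an aromatic carbon). Within the data shown here, the one measured step of the same kind, a 1.1-fold lower number from compound 1 to compound 3 (0.04 log units; within the scatter), barely moved the number, and a 1.8-fold lower number from compound 1 to compound 2 (0.25 log units; within the scatter) likewise stayed within the scatter. A second fluoro is therefore expected to leave this assay essentially unchanged, with no step beyond the scatter in either direction. Compound 4 is accordingly estimated at 850 nM, within a range from 400 nM to 1800 nM, which corresponds to an expected 1.1-fold lower number from compound 3 to compound 4 (0.04 log units; within the scatter).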

Compound 4, half-maximal inhibitory concentration: 1120 nM
The estimate for compound 4 lay 1.3-fold (0.12 log units) below the measured number, within the range that was stated.
By their numbers in this assay, from the lowest: compounds 2, 3, 1 and 4 (each within the scatter of the next).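

Among these compounds, with a fluoro now on an aromatic carbon ortho to a large group and meta to a fluoro group, the change from 4-fluorophenyl to 2,4-difluorophenyl shows that this carbon, which bears hydrogen in the earlier compounds, can take a fluoro in this assay with no step beyond the scatter (a 1.2-fold higher number from compound 3 to compound 4 (0.08 log units; within the scatter)). The 2,4-difluorophenyl group also stays within the scatter of the unsubstituted phenyl (a 1.1-fold higher number from compound 1 to compound 4 (0.04 log units; within the scatter)) and of 4-methylphenyl (a 1.9-fold higher number from compound 2 to compound 4 (0.29 log units; within the scatter)), so no substituent shown on this ring separates from the others. Nothing in hand bears on the reason for this flat picture.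

From the compounds shown here alone, whether any substituent on this ring can move the number beyond the scatter stays open. A methoxy group, an amine or a carboxylic acid on the same carbon would test that.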